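Swapping the aryl group on the piperazine of compound 2

The compounds below may be only part of what the source reports. "The series", "measured", "known", "first", "only" and "open" are said of these compounds alone.

Measured so far in an assay on membranes from Cerebral cortex for binding affinity to Adrenergic receptor alpha-1 (Rattus norvegicus), read by radioligand binding; a higher number here means a weaker inhibitor, a lower number a stronger inhibitor:
compound 1, `COc1ccccc1N1CCN(CCN2C(=O)CC(=C(c3ccccc3)c3ccccc3)C2=O)CC1`, gives 71.5 nM.
compound 2, `O=C1CC(=C(c2ccccc2)c2ccccc2)C(=O)N1CCN1CCN(c2cccc(C(F)(F)F)c2)CC1`, reaches only the limit of the assay, > 1000 nM.

Compound 2 thus stands at the weak end of what this assay can report, with only a limit and no number; the limit of > 1000 nM in this assay, at which 1 of the 2 values shown sits, marks that boundary. Within the data shown here, the one measured step, an at least 13-fold higher number from compound 1 to compound 2 (1.14 log units; beyond the scatter), shows that exchanging the aromatic group on the ring nitrogen can move affinity a long way.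

Compound 3, `O=C1CC(=C(c2ccccc2)c2ccccc2)C(=O)N1CCN1CCN(c2ccc(F)cc2)CC1`, differs from compound 2 in the same region: 4-fluorophenyl in place of 3-(trifluoromethyl)phenyl on an amine nitrogen in a ring. Among the measured compounds shown here, no measured pair mirrors this particular exchange, so the step from compound 1 to compound 2 serves only as a sign that this position is sensitive. With compound 2 already at the limit, the step cannot be read as a loss, and a gain is uncertain; the estimate for compound 3 therefore comes with a wide range.

Compound 3 is estimated at 300 nM, between 60 nM and 1500 nM, which is expected to mean an at least 3.3-fold lower number from compound 2 to compound 3 (0.52 log units; beyond the scatter).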

Compound 3, inhibition constant: 529 nM
Beside the measured number, compound 3's estimate is 1.8-fold (0.25 log units) below it, and the stated range covers the measured number.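

In this assay, among these compounds, compound 3 gives the first measured number at this ring nitrogen for an aryl group other than 2-methoxyphenyl, so the size of such an exchange can now be read directly. Replacing 2-methoxyphenyl with 4-fluorophenyl brings a 7.4-fold higher number from compound 1 to compound 3 (0.87 log units; beyond the scatter), which shows that this position tolerates a change of aryl group with a modest loss of affinity rather than only the much larger one seen with compound 2. The other comparison gives an at least 1.8-fold lower number from compound 2 to compound 3 (0.27 log units; that floor lies within the scatter), and with that floor inside the scatter, the data do not establish that 4-fluorophenyl is better than 3-(trifluoromethyl)phenyl here, as compound 2 has only a limit and the true size of the step stays unknown: the limit of > 1000 nM in this assay, at which 1 of the 3 values shown sits.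

The three aryl groups differ both in what they carry and in where they carry it, so these compounds cannot separate the effect of the group from the effect of its place on the ring. As far as these compounds go, it also remains open how a plain phenyl group, with no fluorine, trifluoromethyl or methoxy on it, would compare at this ring nitrogen.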